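The compounds below may be only part of what the source reports. "The series", "measured", "known", "first", "only" and "open" are said of these compounds alone.

Measured so far:
compound 1, `COC(=O)C1=C(C)NC(C)=C(C(=O)OC)C1c1[nH]cnc1Cl`: 1200 nM
compound 2, `CC1=C(C(=O)OCCCc2ccccc2)C(c2nc[nH]c2Cl)C(C(=O)OCCCc2ccccc2)=C(C)N1`: 1.74 nM

In an assay on isolated protein for inhibition of Voltage-dependent L-type calcium channel subunit alpha-1C (Cavia porcellus) (on this read-out higher numbers stand for weaker inhibition and lower numbers for stronger inhibition), compound 1 gives 1200 nM, the higher of the two numbers; compound 2 gives a far lower number in this assay, a gap well beyond the scatter. Compound 3, `CCCOC(=O)C1=C(C)NC(C)=C(C(=O)OC)C1c1[nH]cnc1Cl`, differs from compound 1 by ethyl in place of hydrogen on a saturated chain carbon bound to an oxygen next to a carbonyl group. With only these two measured compounds, and compound 2 carrying much larger ester groups and a much lower number, the step to a single longer ester is expected to lower the number, by a moderate amount beyond the scatter: a 4.8-fold lower number from compound 1 to compound 3 (0.68 log units; beyond the scatter). Compound 3 is estimated at 250 nM, within 60 nM to 900 nM.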

Compound 3, half-maximal inhibitory concentration: 437 nM
Compound 3: middle estimate off by 1.7-fold (0.24 log units), on the low side, within the range that was stated.
By their numbers in this assay, from the lowest: compound 2; then compound 3; then compound 1.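

In this assay, replacing one methoxycarbonyl with propoxycarbonyl gives a 2.7-fold lower number from compound 1 to compound 3 (0.44 log units; beyond the scatter) and this modest step lies beyond the scatter. It shows that this single change, with the rest of compound 1 kept, is enough on its own to lower the number. Nothing measured here explains why the number moves. On these data alone, whether a butyl chain, a benzyl group or a carboxylic acid in this place would lower the number further stays open. So does whether the same change on the other methoxycarbonyl of compound 3 would give a similar step.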